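The source may report more compounds than this note shows. Statements on the series, on what has been measured and on what is new or still open speak of the compounds shown alone.

Measured compounds:
- compound 1, `CCOC(=O)c1cc(-c2ccccc2)nn1CC(O)COc1ccc(Cl)cc1`: 59000 nM
- compound 2, `CCOC(=O)c1cc(-c2ccccc2)nn1CC(O)COc1ccc([N+](=O)[O-])cc1`: 48000 nM
- compound 3, `CCOC(=O)c1cc(-c2ccccc2)nn1CC(O)COc1ccccc1[N+](=O)[O-]`: 30000 nM

All three were tested in a functional assay on A549 cells (Homo sapiens) for inhibition, read by MTT assay, with a stated time of 48 h; on this read-out lower numbers stand for stronger inhibition and higher numbers for weaker inhibition. The three numbers sit close together: a 2.0-fold lower number from compound 1 to compound 3 (0.29 log units; within the scatter) and a 1.6-fold lower number from compound 2 to compound 3 (0.20 log units; within the scatter), so compound 3 is not set apart from compound 1 or compound 2 by more than the usual spread of repeat measurements. The change from compound 1 to compound 2, a 1.2-fold lower number from compound 1 to compound 2 (0.09 log units; within the scatter), is likewise within the scatter.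

Compound 4, `CCOC(=O)c1cc(-c2ccc(OC)cc2)nn1CC(O)COc1ccccc1[N+](=O)[O-]`, has not yet been measured. It differs from compound 3 in one place: methoxy in place of hydrogen on an aromatic carbon. Among the compounds with values here, this change sits on the phenyl attached to the shared core, whereas every measured step so far concerns the other aromatic ring, the one joined through the oxygen on the saturated carbon. Within the data shown here, none of the measured steps therefore speaks directly to this change. What the measured steps do show is that the series has so far been insensitive to small changes on an aromatic ring, none of them moving beyond the scatter. On that basis compound 4 is expected to give a number close to that of compound 3, with no change at the digits printed from compound 3 to compound 4 (within the scatter), the estimate for compound 4 being 30000 nM with a range from 10000 nM to 90000 nM.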

Compound 4, half-maximal inhibitory concentration: 45000 nM
Estimate against measurement, compound 4: 1.5-fold (0.18 log units) below; measured number inside the range.
By their numbers in this assay, from the lowest: compounds 3, 4, 2 and 1 (each within the scatter of the next).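

Within the data shown here, compound 4 is the first compound here with a change on the phenyl attached to the shared core, a ring that stays unchanged across compounds 1, 2 and 3. In this assay the change from phenyl to 4-methoxyphenyl, with methoxy para to a large group, gives a 1.5-fold higher number from compound 3 to compound 4 (0.18 log units; within the scatter) and so does not separate the two compounds beyond the usual spread of repeat measurements. The insensitivity seen so far on the ring joined through oxygen therefore has its first counterpart on this other ring, though from a single change, and no measurement here offers an explanation for the small size of this step.

Among the compounds shown, methoxy is the only group other than hydrogen at this position, so one substituent cannot show how the number would respond to an amine, a carboxylic acid or a longer chain such as butoxy in the same place. From the compounds shown here alone, it also remains open whether any change on this ring can produce a step beyond the scatter, or whether the same methoxy would behave alike with the other rings joined through oxygen.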